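The compounds below may be only part of what the source reports. "The series", "measured", "known", "first", "only" and "open" are said of these compounds alone.

Measured compounds:
compound 1, `CCS(=O)(=O)Nc1cc(-c2ccc3ncnc(Nc4cccc(F)c4)c3c2)cnc1OC`: 8020 nM
compound 2, `CCS(=O)(=O)Nc1cc(-c2ccc3ncnc(Nc4ccc(C(=O)OC)c(OC)c4)c3c2)cnc1OC`: 10900 nM
compound 3, `CCS(=O)(=O)Nc1cc(-c2ccc3ncnc(Nc4ccc(F)nc4)c3c2)cnc1OC`: 5390 nM

All three numbers come from a functional assay on MCF7 cells (Homo sapiens) for cytotoxicity, read by sulforhodamine B assay, with a stated time of 72 h; on this read-out higher numbers stand for weaker inhibition and lower numbers for stronger inhibition. Compound 1 holds the second highest of the three numbers; its neighbours lie close on either side, with a 1.4-fold higher number from compound 1 to compound 2 (0.13 log units; within the scatter) and a 1.5-fold lower number from compound 1 to compound 3 (0.17 log units; within the scatter), so nothing separates compound 1 from either partner beyond the scatter. For the measured compounds named here, the one step in the set that clears the scatter is a 2.0-fold lower number from compound 2 to compound 3 (0.31 log units; beyond the scatter), and it is modest.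

Compound 4, `CCS(=O)(=O)Nc1cc(-c2ccc3ncnc(Nc4ccc(OC)nc4)c3c2)cnc1OC`, is not yet measured. It departs from compound 1 by 6-methoxypyridin-3-yl in place of 3-fluorophenyl on a nitrogen on an aromatic ring. Going by the values given here, the nearest measured step is the one from compound 1 to compound 3, where a 6-fluoropyridin-3-yl also replaced the 3-fluorophenyl on the same nitrogen and the number moved only within the scatter. The step from compound 1 to compound 2, a different group on that nitrogen, likewise stayed within the scatter. On that basis no step beyond the scatter is expected for compound 4 in this assay, and the estimated step is a 1.2-fold lower number from compound 1 to compound 4 (0.09 log units; within the scatter). The expected value for compound 4 is 6500 nM, with a range from 3000 nM to 14000 nM.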

Compound 4, half-maximal inhibitory concentration: 3770 nM
Estimate against measurement, compound 4: 1.7-fold (0.24 log units) above; measured number inside the range.
By their numbers in this assay, from the lowest: compounds 4, 3, 1 and 2 (each within the scatter of the next, the first and the last beyond it).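

In this assay, 6-methoxypyridin-3-yl on the nitrogen gives the first step away from the 3-fluorophenyl group of compound 1 that clears the scatter, a 2.1-fold lower number from compound 1 to compound 4 (0.33 log units; beyond the scatter), whereas 6-fluoropyridin-3-yl at the same place stayed within it. This does not separate the two pyridinyl groups, since methoxy in place of fluoro on an aromatic carbon gives only a 1.4-fold lower number from compound 3 to compound 4 (0.16 log units; within the scatter). The largest step in the set is now a 2.9-fold lower number from compound 2 to compound 4 (0.46 log units; beyond the scatter), for 6-methoxypyridin-3-yl in place of 3-methoxy-4-(methoxycarbonyl)phenyl, and it is still modest.

No available evidence bears on what lies behind these differences. Open, going by these compounds, is whether an amine, a carboxylic acid or a longer alkoxy chain such as ethoxy in place of the methoxy on the pyridinyl ring would move the number further in either direction.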